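Stilbene series: cytotoxicity limits and a benzyl-to-acetyl step

The source may report more compounds than this note shows. Statements on the series, on what has been measured and on what is new or still open speak of the compounds shown alone.

Measured compounds:
compound 1 `COc1cc(/C=C/c2ccc(C(C)(C)C)cc2)cc(OC)c1OC`: in a functional assay on MLM cells (Homo sapiens) for cytotoxicity, using microsomes (on this read-out higher numbers stand for an effect only at larger amounts of compound and lower numbers for an effect already at smaller amounts), compound 1 gives > 25 uM, a limit of the assay rather than a number.
compound 2 `COc1ccc(/C=C\c2cc(OC)c(OCc3ccccc3)c(OC)c2)cc1`: in this assay compound 2 gives > 25 uM, again a limit of the assay.

Compound 2 therefore stands at the limit, not at a measured number; the same holds for the other measured compound, as the limit of > 25 uM in this assay, at which 2 of the 2 values shown sit, shows. Within the data shown here, no step between measured compounds can be read from these two values. The unmeasured compound 3 `COc1ccc(/C=C\c2cc(OC)c(OC(C)=O)c(OC)c2)cc1` differs from compound 2 by acetyl in place of benzyl on an oxygen on an aromatic ring. With both measured values sitting at the limit, the change is expected to be a step that the limit leaves unreadable from compound 2 to compound 3, that is none beyond the scatter in this assay. For compound 3 the estimate in this assay is 30 uM, with a range from 12 uM to 80 uM, and the result is expected most likely to be reported as a limit once more.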

Compound 3, concentration for half-maximal effect: > 25 uM
Compound 3 was reported as a limit (the forecaster's own chance of this, stated with the estimate: 80%); the middle value lies beyond the limit too.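

No step can be read from compound 2 to compound 3 in this assay, as neither compound gives a number: the limit of > 25 uM in this assay, at which 3 of the 3 values shown sit.

The compounds shown leave open at what concentration any of them acts, and whether acetyl in place of benzyl changes the read-out at all.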